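This account rests on a few compounds, and the source may have more. Where it says the series, first, only, none or still open, it means among the compounds named here.

Of the compounds shown here, three sharing one core have been tested in a functional assay on K562 cells (Homo sapiens) for cytotoxicity, read by CCK-8 assay, with a stated time of 72 h; on this read-out lower numbers stand for stronger inhibition and higher numbers for weaker inhibition. Compound 1 `C=CCn1c(=O)/c(=C\c2ccc(Cl)c(Cl)c2)[nH]c(=O)/c1=C\c1ccccc1` is reported in this assay as "not active" (no number reported), with no number attached. Compound 2 `C=CCn1c(=O)/c(=C\c2cc(F)ccc2C)[nH]c(=O)/c1=C\c1ccccc1OC` gives 1800 nM in this assay. Compound 3 `COc1ccccc1/C=c1/[nH]c(=O)/c(=C\c2nc[nH]c2C(C)(C)C)[nH]c1=O` gives 60 nM in this assay. Of the two numbers obtained, compound 2 stands at the higher one. The gap between compound 2 and compound 3 lies well beyond the usual scatter of this assay, and compound 2 is the weaker of those two. Compound 4 `C=CCn1c(=O)/c(=C\c2ccccc2Cl)[nH]c(=O)/c1=C\c1ccccc1OC` has not yet been measured. It differs from compound 2 in one place: 2-chlorophenyl in place of 5-fluoro-2-methylphenyl on a double-bonded chain carbon bound to an aromatic carbon. Going by the values given here, no pair of measured compounds differing only in this place is available, so the direction of the step cannot be read from a measured precedent. Compound 1 differs from compound 2 in more than one place and came out as not active, which gives no clean guide to this single exchange. Compound 4 is therefore expected to stay close to compound 2, with a step of a 1.2-fold higher number from compound 2 to compound 4 (0.09 log units; within the scatter) in this assay, within or near the usual scatter. The estimate for compound 4 in this assay is 2200 nM, with a range from 800 nM to 6500 nM.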

Compound 4, half-maximal inhibitory concentration: 2500 nM
Beside the measured number, compound 4's estimate is 1.1-fold (0.06 log units) below it; low and high end bracket the measured number.
By their numbers in this assay, from the lowest: compound 3; then compounds 2 and 4 (each within the scatter of the next).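

At the double-bonded chain carbon bound to an aromatic carbon, the exchange of 5-fluoro-2-methylphenyl for 2-chlorophenyl gives the first step read at this position in this assay, and it is small: a 1.4-fold higher number from compound 2 to compound 4 (0.14 log units; within the scatter). Both groups hold one six-membered aromatic ring of carbon only, and one carries fluorine and a methyl group where the other carries chlorine, yet the two compounds cannot be told apart in this assay, so this position accepts either substituted phenyl without a measurable difference. Nothing measured bears on why the two groups read alike.

Neither group has a hydrogen-bond donor or acceptor, so the compounds shown leave open whether a phenyl ring carrying a carboxylic acid or a dimethylamino group at this place would move the number beyond the scatter. Going by these compounds, compound 3 differs from compound 2 and compound 4 in more than one place, so how much of its lower number belongs to this position also stays open.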